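The compounds below may be only part of what the source reports. "The series", "measured", "known", "first", "only" and "open" are said of these compounds alone.

In a functional assay on GC3/C1 cells (Homo sapiens) for cytotoxicity, read by MTT assay, with a stated time of 6 days (on this read-out higher numbers stand for weaker inhibition and lower numbers for stronger inhibition), compound 1 `CC(=O)N[C@@H](CSC(=O)Nc1ccccc1Cl)C(=O)O` gives only a limit of the assay, > 200000 nM, and no number. Compound 2 `COc1ccc(NC(=O)SC[C@H](NC(C)=O)C(=O)O)cc1` likewise sits at a limit of this assay, > 200000 nM, so both values shown stand at the same limit (the limit of > 200000 nM in this assay, at which 2 of the 2 values shown sit). Compound 3 `CC(=O)N[C@@H](CSC(=O)Nc1ccc(Br)cc1)C(=O)O` differs from compound 2 by bromo in place of methoxy on an aromatic carbon. No step between measured compounds is shown, so the data give nothing to set a direction. Compound 3 is expected to remain at that limit, and the step of a number no higher from compound 2 to compound 3 (the limit leaves the size open) is estimated as none beyond the scatter. The estimate for compound 3 is 200000 nM, with a range from 80000 nM to 500000 nM.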

Compound 3, half-maximal inhibitory concentration: 63500 nM
For compound 3 the middle estimate is 3.1-fold (0.50 log units) above the measured one; the whole stated range lies above it.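

In this assay the change from methoxy to bromo on an aromatic carbon, para to a large group, gives an at least 3.1-fold lower number from compound 2 to compound 3 (0.49 log units; beyond the scatter) and so shows that this position can move the read-out. Among the compounds shown here, compound 3 is the first compound here to give a real number rather than a limit. The true size of the step stays open because compound 2 gives only a limit: the limit of > 200000 nM in this assay, at which 2 of the 3 values shown sit 

From the compounds shown here alone, whether a smaller halogen such as fluoro, an amine or a longer chain at this place would do the same remains open.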